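Pyrrolyl for pyridyl in a weakly active amide series

The source may hold more compounds than are shown below. What is called first, only, known or untested is meant among the compounds shown, and "the series" means these compounds.

Working notes. The series shares a piperidine carboxamide core bearing a difluorobenzyl group; it is read in a functional assay on A-375 cells (Homo sapiens) for antiproliferative activity; a lower number here means a stronger inhibitor, a higher number a weaker inhibitor. Compound 1 `O=C(Nc1ccc2scnc2c1)C1CCCN(Cc2ccc(F)c(F)c2)C1` reaches only the limit of the assay, > 20000 nM, which is a limit and not a number (the limit of > 20000 nM in this assay, at which 1 of the 3 values shown sits). Compound 2 `O=C(Nc1ccc(-c2cscn2)cc1)[C@@H]1CCCN(Cc2ccc(F)c(F)c2)C1` gives 6000 nM. Compound 3 `O=C(Nc1ccc(-c2ccccn2)cc1)C1CCCN(Cc2ccc(F)c(F)c2)C1` gives 9000 nM; compound 3 and compound 2 lie within the usual scatter of each other, so no order between them is claimed. Compound 4 `O=C(Nc1ccc(-c2cc[nH]c2)cc1)C1CCCN(Cc2ccc(F)c(F)c2)C1` is the next member: 1H-pyrrol-3-yl in place of pyridin-2-yl on an aromatic carbon. Among the compounds with values here, no measured pair in the set shows the effect of such an exchange, so the step in this assay is expected to be small, with no clear direction beyond the scatter, and a weak inhibitor is anticipated. For compound 4 the estimate in this assay is 8000 nM, between 2500 nM and 25000 nM, which corresponds to an expected step of a 1.1-fold lower number from compound 3 to compound 4 (0.05 log units; within the scatter).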

Compound 4, half-maximal inhibitory concentration: 1420 nM
Compound 4: middle estimate off by 5.6-fold (0.75 log units), on the high side, and the stated range ends above it.
By their numbers in this assay, from the lowest: compound 4; then compounds 2 and 3 (each within the scatter of the next). At a limit, above all of these: compound 1.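

In this assay, within the data shown here, 1H-pyrrol-3-yl in place of pyridin-2-yl gives a 6.3-fold lower number from compound 3 to compound 4 (0.80 log units; beyond the scatter) and shows that this position, on an aromatic carbon para to a large group, responds to the ring placed there, which no earlier pair could show. The exchange alters ring size and swaps a hydrogen-bond acceptor for a hydrogen-bond donor at once, so this single modest step cannot separate the two changes. Nothing in the data gives a reason for the lower number.

Open, as far as these compounds go, is whether the hydrogen on the pyrrole nitrogen goes with the lower number, which a 1-methylpyrrol-3-yl or furan-3-yl ring at the same place would test. Also open, from the compounds shown here alone, is how an amine or a carboxylic acid on this ring would read out.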